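Swapping the amide ring on the weakest of three compounds

The source may report more compounds than this note shows. Statements on the series, on what has been measured and on what is new or still open speak of the compounds shown alone.

Going by the values given here, in a functional assay on MDA-MB-231 cells (Homo sapiens) for cytotoxicity, read by MTT assay, with a stated time of 72 h (on this read-out lower numbers stand for stronger inhibition and higher numbers for weaker inhibition), compound 2 `O=C(CN1CCN(c2nnc(Cc3ccccc3)c3ccccc23)CC1)Nc1ccc(F)c(F)c1` gives 2750 nM, the highest number of the three measured so far and so the weakest result. Compound 1 `O=C(CN1CCN(c2nnc(Cc3ccncc3)c3ccccc23)CC1)Nc1cccc(Br)c1` gives 1.7 nM, and compound 3 `O=C(CN1CCN(c2nnc(Cc3ccncc3)c3ccccc23)CC1)Nc1ccc(F)c(F)c1` gives 0.84 nM. The open case is compound 4 `O=C(CN1CCN(c2nnc(Cc3ccccc3)c3ccccc23)CC1)Nc1cccc(Br)c1`. It keeps the phenyl group of compound 2 but carries 3-bromophenyl in place of 3,4-difluorophenyl on an amide-type nitrogen.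

One measured step holds the same swap, run the other way and among the pyridin-4-yl compounds: a 2.0-fold lower number from compound 1 to compound 3 (0.31 log units; beyond the scatter). That step is modest, and read backwards it suggests a slightly higher number with 3-bromophenyl. The other step, a 3300-fold lower number from compound 2 to compound 3 (3.52 log units; beyond the scatter), is large, but it comes with pyridin-4-yl in place of phenyl, a change compound 4 does not make. So compound 4 is expected to stay close to compound 2 at 2750 nM, far from the low numbers of the pyridin-4-yl pair. A single pair is thin evidence, and the swap may behave differently on the phenyl compounds.

A modest upward move is expected, a 1.8-fold higher number from compound 2 to compound 4 (0.26 log units; within the scatter). In this assay the estimated value for compound 4 is 5000 nM, with an expected range from 1200 nM to 20000 nM.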

Compound 4, half-maximal inhibitory concentration: 3880 nM
Estimate against measurement, compound 4: 1.3-fold (0.11 log units) above, within the range that was stated.
By their numbers in this assay, from the lowest: compound 3; then compound 1; then compounds 2 and 4 (each within the scatter of the next).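

Putting 3-bromophenyl in place of 3,4-difluorophenyl on an amide-type nitrogen makes little difference when the saturated chain carbon carries phenyl: in this assay the result is a 1.4-fold higher number from compound 2 to compound 4 (0.15 log units; within the scatter), which is no more than the usual variation between repeated measurements. This swap can now be read on two cores, and the two readings agree: the same change on two cores in this assay, a 2.0-fold lower number (0.31 log units; beyond the scatter) from compound 1 to compound 3 and a 1.4-fold lower number (0.15 log units; within the scatter) from compound 4 to compound 2, 1.4-fold (0.16 log units) apart, within the scatter of two such steps. The large gap between phenyl and pyridin-4-yl also appears with 3-bromophenyl (a 2300-fold higher number from compound 1 to compound 4 (3.36 log units; beyond the scatter)), so it no longer rests on a single pair, and the size of this gap holds with either amide ring: the same change on two cores in this assay, a 3300-fold lower number (3.52 log units; beyond the scatter) from compound 2 to compound 3 and a 2300-fold lower number (3.36 log units; beyond the scatter) from compound 4 to compound 1, 1.4-fold (0.16 log units) apart, within the scatter of two such steps.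

Going by these compounds alone, only two groups appear at each place, so it remains open whether pyridin-3-yl or a simple amine on the chain carbon would keep the low numbers of compound 1 and compound 3. It is also unknown whether the amide ring can vary more widely, for example to 4-methoxyphenyl or a longer chain such as phenethyl, and still make so little difference, and these four compounds cannot say why pyridin-4-yl matters so much.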